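The source may hold more compounds than are shown below. What is called first, only, known or untested is meant among the compounds shown, and "the series" means these compounds.

The series shares one core, varied at a single aromatic carbon. Compound 1 `CCCCCCCCOc1nc(N)nc2c1ncn2/C=C1/CC1(CO)CO` carries octyloxy there; in an ADME assay on HFF cells (Homo sapiens) for cytotoxicity, with a stated time of 8 days (a lower number here means that less compound is tolerated, a higher number that more compound is tolerated), compound 1 gives > 300000 nM, which is a limit of the assay rather than a number. Compound 2 `CCCSc1nc(N)nc2c1ncn2/C=C1/CC1(CO)CO` carries propylsulfanyl; in this assay compound 2 gives > 300000 nM, again a limit. Compound 3 `Nc1nc(SC2CCCC2)c2ncn(/C=C3/CC3(CO)CO)c2n1` carries cyclopentylsulfanyl; in this assay compound 3 gives > 300000 nM, also a limit. Where compound 2 stands is thus known only as a limit, and the two further values shown are limits as well. The measured steps are accordingly unreadable: a step that the two limits leave unreadable from compound 1 to compound 2, a step that the two limits leave unreadable from compound 1 to compound 3 and a step that the two limits leave unreadable from compound 2 to compound 3. The one common observation is the limit of > 300000 nM in this assay, at which 3 of the 3 values shown sit.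

Compound 4 `CCCCSc1nc(N)nc2c1ncn2/C=C1/CC1(CO)CO` is not yet measured. It differs from compound 2 by methyl in place of hydrogen on a saturated chain carbon, three bonds along the chain from a sulfur. Among the measured compounds shown here, none of the measured steps has a readable size, so they bear on the new step only in that every value so far sits at the limit. With three limits and no direction in hand, no step beyond the scatter is expected in this assay from this change; the step expected is a step that the limit leaves unreadable from compound 2 to compound 4. For compound 4 in this assay the estimate is 350000 nM, with a range from 150000 nM to 1000000 nM, most probably reported again as a limit.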

Compound 4, half-maximal cytotoxic concentration: > 300000 nM
Compound 4: only a limit was reported (the forecaster's own chance of this, stated with the estimate: 85%); the middle value does not contradict the limit.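

Compound 4 also reads only as a limit, so the steps to it from compound 1, compound 2 and compound 3 cannot be read in this assay: the limit of > 300000 nM in this assay, at which 4 of the 4 values shown sit. The compounds shown leave open where the half-maximal cytotoxic concentration of any of them lies, and whether any change at the varied aromatic carbon shifts it.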